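A few compounds are considered here, and "the series" means these few. Any claim that something is new, unique, unknown or untested is made for them only; others in the source may bear on it.

Compound 1 `CCCNS(=O)(=O)c1ccc(Nc2ncc3c(n2)N(C2CCCC2)[C@H](CC)C(=O)N3C)cc1` gives 344 nM in a functional assay on MCF7 cells (Homo sapiens) for antiproliferative activity, read by CCK-8 assay, with a stated time of 72 h; a higher number here means a weaker inhibitor of growth, a lower number a stronger inhibitor of growth.
Compound 2 `CCC1C(=O)N(C)c2cnc(-n3ccc4cc(C(=O)NC)ccc43)nc2N1c1ccn(C)n1` gives 35400 nM in this assay.
Compound 3 `CCC1C(=O)N(C)c2cnc(Nc3ccc(S(=O)(=O)NC)cc3)nc2N1c1ccn(C)n1` gives 3750 nM in this assay.

Among these three, compound 1 has the lowest number and so is the strongest inhibitor of growth; the gap to compound 3 and the larger gap to compound 2 both lie beyond the usual scatter. Compound 4 `CCCCNS(=O)(=O)c1ccc(Nc2ncc3c(n2)N(C2CCCC2)[C@H](CC)C(=O)N3C)cc1` has not yet been measured. It differs from compound 1 in one place: methyl in place of hydrogen on a saturated chain carbon, three bonds along the chain from a sulfonamide nitrogen. Adding one carbon to a chain at this position is a small change, and no measured pair shows its effect directly. The step from compound 1 to compound 4 is therefore expected to be small, with no clear direction, likely within the scatter: a 1.0-fold higher number from compound 1 to compound 4 (0.01 log units; within the scatter). Compound 4 is estimated at 350 nM, between 150 nM and 800 nM.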

Compound 4, concentration for 50% growth inhibition: 459 nM
Estimate against measurement, compound 4: 1.3-fold (0.12 log units) below; the range from low to high includes it.
By their numbers in this assay, from the lowest: compounds 1 and 4 (each within the scatter of the next); then compound 3; then compound 2.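

Going from propyl to butyl on this chain gives a 1.3-fold higher number from compound 1 to compound 4 (0.13 log units; within the scatter) in this assay. This is the first pair shown that differs in one place, and it indicates that this position accepts one more carbon with no difference beyond the scatter. Nothing measured here explains the result.

Going by these compounds, whether a longer chain such as hexyl would stay within the scatter of compound 1 remains open. So does the outcome for a chain ending in an amine or a carboxylic acid.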